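The source may hold more compounds than are shown below. What is called first, only, known or untested is meant among the compounds shown, and "the series" means these compounds.

In a physicochemical assay, at pH 7.4 (a higher number here means that the compound lasts longer, a lower number that the compound disappears faster), compound 1 `CO[C@H]1C(=O)N2C(C(=O)C(C)(C)C)=C(C)[C@@H](OC(=O)C(C)(C)C)S(=O)(=O)C12` gives 54 h, and compound 2 `CO[C@H]1C(=O)N2C(C(=O)C(C)(C)C)=C(C)[C@@H](OC(=O)CCC(=O)c3ccccc3)S(=O)(=O)C12` gives 13 h. Within the data shown here, compound 2 stands at the lowest of the two numbers known so far; its nearest neighbour is compound 1, and the only measured step, a 4.2-fold lower number from compound 1 to compound 2 (0.62 log units; beyond the scatter), lies beyond the scatter. Compound 3 `CO[C@H]1C(=O)N2C(C(=O)C(C)(C)C)=C(C)[C@@H](OC(=O)c3ccc4ccccc4c3)S(=O)(=O)C12` has not yet been measured. It differs from compound 2 in one place: naphthalen-2-yl in place of 2-benzoylethyl on a carbonyl carbon. Among the measured compounds shown here, the measured step from compound 1 to compound 2 bears on this change only in that it also swaps the group on the same carbonyl carbon; no measured pair exchanges an aromatic group for the 2-benzoylethyl group, so the direction of the new step cannot be read directly from the numbers. Because a 4.2-fold lower number from compound 1 to compound 2 (0.62 log units; beyond the scatter) showed that a change at this carbonyl carbon moves the half-life, a further change there is expected to move it again, and the expected step is a 2.3-fold higher number from compound 2 to compound 3 (0.36 log units; beyond the scatter). For compound 3 the estimate in this assay is 30 h, with a range from 10 h to 90 h.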

Compound 3, half-life: 33 h
Beside the measured number, compound 3's estimate is 1.1-fold (0.04 log units) below it; the range from low to high includes it.
By their numbers in this assay, from the lowest: compound 2; then compounds 3 and 1 (each within the scatter of the next).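

In this assay, putting naphthalen-2-yl in place of 2-benzoylethyl on this carbonyl carbon gives a 2.5-fold higher number from compound 2 to compound 3 (0.40 log units; beyond the scatter), so two groups with the same count of heavy atoms can still end up clearly apart, and that count alone does not settle the half-life here. The second comparison, a 1.6-fold lower number from compound 1 to compound 3 (0.21 log units; within the scatter), lies within the scatter, which means tert-butyl, with no aromatic ring, and naphthalen-2-yl, with two, cannot be told apart at this position, and among these three compounds only the 2-benzoylethyl group of compound 2 stands out from the others. No measurement is available that explains why the half-life shifts with these groups.

The compounds shown do not separate the parts of the 2-benzoylethyl group, so it remains open whether its chain, its ketone carbonyl or its phenyl ring goes with the shorter half-life. A plain propyl chain, a simple phenyl ring or a chain ending in a carboxylic acid on this carbonyl carbon would each help to pull those parts apart.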